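A few compounds are considered here, and "the series" means these few. Any claim that something is new, unique, unknown or untested is made for them only; others in the source may bear on it.

Measured compounds:
compound 1, `COc1cc(/C=C/C(=O)Nc2ccccc2)ccc1OCCCCN(C)C`, 1.57
compound 2, `COc1cc(/C=C/C(=O)Nc2ccccc2)ccc1OCCCCCN(C)C`, 1.61
compound 3, `COc1cc(/C=C/C(=O)Nc2ccccc2)ccc1OCCCCCCN1CCCC1`, 1.76

Compound 3 gives the highest of the three numbers in a physicochemical assay for lipophilicity, using the shake flask method, measured as octanol-water partition, at pH 7.4 (on this read-out lower numbers stand for lower lipophilicity and higher numbers for higher lipophilicity), but its separation from the other two is small: a number 0.15 log units higher from compound 2 to compound 3 (within the scatter) and a number 0.19 log units higher from compound 1 to compound 3 (within the scatter), both inside the scatter, so no order among the three can be claimed. Compound 4, `COc1cc(/C=C/C(=O)Nc2ccccc2)ccc1OCCCCCCCCCCN(C)C`, has not been measured in this assay. It differs from compound 3 by 4-(dimethylamino)butyl in place of pyrrolidin-1-yl on a saturated chain carbon, six bonds along the chain from an oxygen on an aromatic ring.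

Among the compounds with values here, two measured steps bear on this change. Lengthening the chain by one carbon, a number 0.04 log units higher from compound 1 to compound 2 (within the scatter), produced no step beyond the scatter. Exchanging dimethylamino for the pyrrolidinyl ring while adding a chain carbon, a number 0.15 log units higher from compound 2 to compound 3 (within the scatter), also stayed inside the scatter. The step to compound 4 is larger than either: the pyrrolidinyl ring leaves and a chain of four further carbons carrying dimethylamino enters. The account therefore expects the number to move upward, by more than the measured steps, since several added chain carbons are combined here. Compound 4 is estimated at 2.5, within 1.9 to 3.2, which would mean an expected step of a number 0.74 log units higher from compound 3 to compound 4 (beyond the scatter).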

Compound 4, partition coefficient: 1.8
The estimate for compound 4 lay 0.70 log units above the measured number; measured number outside the range, below it.
By their numbers in this assay, from the lowest: compounds 1, 2, 3 and 4 (each within the scatter of the next).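

In this assay, giving up the pyrrolidinyl ring for the longer chain carrying dimethylamino gives a step that stays within the scatter: a number 0.04 log units higher from compound 3 to compound 4 (within the scatter). Read against the two dimethylamino compounds with shorter chains, the longest chain shown also stays within the scatter, with a number 0.19 log units higher from compound 2 to compound 4 (within the scatter) and a number 0.23 log units higher from compound 1 to compound 4 (within the scatter), so the four compounds cannot be separated on this read-out, even though the earlier compounds had covered only a small extension of the chain and the ring exchange. Nothing offered here gives a reason for this result.

The compounds shown leave open whether a still longer chain, or one ending in a piperidine or morpholine ring instead of dimethylamino or pyrrolidin-1-yl, would also stay within the scatter of these four. They also leave open whether a carboxylic acid or a hydroxyl group at the end of the chain, in place of the amine, would give a step beyond it.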